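From Chloro to Hydroxy in a Fibroblast Cytotoxicity Series

A few compounds are considered here, and "the series" means these few. Any claim that something is new, unique, unknown or untested is made for them only; others in the source may bear on it.

Compound 1 `COc1cccc(/C=C2\CCC/C(=C\c3ccccc3Cl)C2=O)c1OC` and compound 2 `COc1ccc(/C=C2\CCC/C(=C\c3ccc(Cl)cc3)C2=O)cc1OC` share one core and were both examined in an ADME assay on NHDF cells (Homo sapiens) for cytotoxicity, read by MTT assay, with a stated time of 72 h; a lower number here means a stronger inhibitor, a higher number a weaker inhibitor. In this assay compound 1 gives 44200 nM. In this assay, for the measured compounds named here, compound 2 gives 11200 nM, the lowest of the two numbers so far; its only neighbour, compound 1, sits at a higher number by a margin beyond the usual scatter. Going by the values given here, no single-point step between two measured compounds is available, so the pair shows only these two values and nothing more.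

Compound 3 `COc1ccc(/C=C2\CCC/C(=C\c3ccc(O)cc3)C2=O)cc1OC` has not yet been measured in this assay. It differs from compound 2 in one place: hydroxy in place of chloro on an aromatic carbon. Among the compounds with values here, no measured step of this kind exists in the set, so the expectation rests on compound 2 alone. Compound 3 is expected to give a somewhat higher number than compound 2. The expected change is a 1.6-fold higher number from compound 2 to compound 3 (0.21 log units; within the scatter), a step that may stay within the scatter or edge just beyond it. For compound 3 the estimate in this assay is 18000 nM, with a range from 7000 nM to 50000 nM.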

Compound 3, half-maximal inhibitory concentration: 26100 nM
The estimate for compound 3 lay 1.5-fold (0.16 log units) below the measured number; the measured number falls inside the stated range.
By their numbers in this assay, from the lowest: compound 2; then compounds 3 and 1 (each within the scatter of the next).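

In this assay, the series now has its first change at a single place, and replacing chloro with hydroxy on the aromatic carbon gives a 2.3-fold higher number from compound 2 to compound 3 (0.37 log units; beyond the scatter), a modest step. This shows that the group at this position, para to a large group, can shift the number beyond the usual scatter with the rest of the structure unchanged, which the earlier pair could not show because its members differ in more than one place. Nothing available here explains why the 4-hydroxyphenyl compound gives the higher number of the two.

On these data alone, a single exchange gives only one direction at one position, so it remains open whether an amine, a fluoro group or a carboxylic acid in the same place would give a number nearer to compound 2, nearer to compound 3 or outside both. As far as these compounds go, it is also open whether hydroxy in place of chloro would give a step of similar size with the two methoxy groups placed as in compound 1, or with the chloro group placed as it is there.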